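This account rests on a few compounds, and the source may have more. Where it says the series, first, only, none or still open, it means among the compounds named here.

Measured compounds:
Compound 1 `O=C(c1ccccc1)c1ccn(-c2ccc3c(c2)B(O)OC3)c1`: in an ADME assay on L929 cells (Mus musculus) for cytotoxicity, read by resazurin assay, with a stated time of 72 h (on this read-out lower numbers stand for stronger inhibition and higher numbers for weaker inhibition), compound 1 gives > 10 ug/mL, which is a limit of the assay and not a number.
Compound 2 `Cc1ccc(C(=O)c2ccn(-c3ccc4c(c3)B(O)OC4)c2)cc1`: in this assay compound 2 gives > 10 ug/mL, also a limit.
Compound 3 `O=C(c1ccn(-c2ccc3c(c2)B(O)OC3)c1)c1cccs1`: in this assay compound 3 gives > 10 ug/mL, again a limit.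

All three values sit at the limit of > 10 ug/mL in this assay, at which 3 of the 3 values shown sit. The step that the two limits leave unreadable from compound 1 to compound 2 cannot be sized, and the same holds for a step that the two limits leave unreadable from compound 1 to compound 3 and a step that the two limits leave unreadable from compound 2 to compound 3: the shared core carries a benzoyl, a 4-methylbenzoyl or a thiophene-2-carbonyl group without any readable difference in this assay.

Compound 4 `Cc1ccc(C(=O)c2ccn(-c3ccc4c(c3)B(O)OC4)c2)s1` has not been measured. It arises from compound 3 by methyl in place of hydrogen on an aromatic carbon. The same kind of change has been made once before, from compound 1 to compound 2, as methyl in place of hydrogen on an aromatic carbon, where the step was a step that the two limits leave unreadable from compound 1 to compound 2. The two cores differ as given by thiophen-2-yl in place of phenyl on a carbonyl carbon. The two places are not the same: in the earlier case the methyl enters on an aromatic carbon of a six-membered aromatic ring of carbon only, para to a large group, whereas here it enters on an aromatic carbon of a five-membered aromatic ring with 1 sulfur, next to the ring sulfur, two ring bonds from the ring atom that bears a large group, so this is the same kind of change, not the same change.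

The step that the limit leaves unreadable from compound 3 to compound 4 is expected to stay unreadable, beside a step that the two limits leave unreadable from compound 1 to compound 2, because compound 3 already sits at the limit of > 10 ug/mL in this assay, at which 3 of the 3 values shown sit. Compound 4 is therefore expected to give about 15 ug/mL in this assay, estimated between 8 ug/mL and 40 ug/mL.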

Compound 4, half-maximal inhibitory concentration: > 10 ug/mL
Compound 4: a limit, no number; the forecaster's own chance of this, stated with the estimate: 85%; the middle value does not contradict the limit.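

In this assay compound 4 gives > 10 ug/mL, a limit and not a number. No step among compound 1, compound 2, compound 3 and compound 4 can be read, because all of them share one limit: the limit of > 10 ug/mL in this assay, at which 4 of the 4 values shown sit.

The compounds shown leave open where each true value lies beyond that limit, and whether the methyl or the thiophen-2-yl changes it at all.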